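Trifluoromethyl for ethyl on the core of compound 1

A few compounds are considered here, and "the series" means these few. Any claim that something is new, unique, unknown or untested is made for them only; others in the source may bear on it.

Measured compounds:
- compound 1, `CCc1cccc2cc(C(=O)O)cnc12`, 75 mg/kg
- compound 2, `c1nc2ccc(C3CCCCC3)cc2cc1-c1nn[nH]n1`, > 25 mg/kg

Among the compounds with values here, in a functional assay on the whole organism (strain Sprague-Dawley) for inhibition, with Rattus norvegicus as the target (a lower number here means that less compound is needed, a higher number that more compound is needed for the effect), compound 1 gives 75 mg/kg, the only plain number in the set. For compound 2 the result is a limit of the assay, > 25 mg/kg, and not a number; this is the situation described as the limit of > 25 mg/kg in this assay, at which 1 of the 2 values shown sits. Within the data shown here, compound 1 therefore stands alone as the single measured point from which anything can be expected, and no step between two measured compounds is available to show how a change at its core moves the dose.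

The unmeasured compound 3, `O=C(O)c1cnc2c(C(F)(F)F)cccc2c1`, differs from compound 1 in one place: trifluoromethyl in place of ethyl on an aromatic carbon. Among the measured compounds shown here, no measured pair here shows what this kind of exchange does, so the expected step from compound 1 to compound 3 is taken as none beyond the scatter, no change at the digits printed from compound 1 to compound 3 (within the scatter), in either direction. On that basis compound 3 is estimated to give 75 mg/kg in this assay, with a range from 30 mg/kg to 180 mg/kg.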

Compound 3, minimum effective dose: 75 mg/kg
Estimate against measurement, compound 3: no gap at the digits printed, within the range that was stated.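

Within the data shown here, this is the first step between two measured compounds in the set: in this assay, trifluoromethyl in place of ethyl on an aromatic carbon gives no change at the digits printed from compound 1 to compound 3 (within the scatter). At this place on the shared core, a group of 4 heavy atoms, 3 of them fluorine, can therefore stand where a group of 2 carbon atoms stood without a readable shift in the minimum effective dose, which compound 1 alone could not show. Nothing measured here gives a reason for this outcome, and a single pair cannot say whether the same holds for other exchanges.

From the compounds shown here alone, whether a smaller group such as methyl, a longer chain such as butyl, or an amine at this same place would also leave the dose needed unchanged remains open. Compound 2 gives > 25 mg/kg, which is a limit of the assay and not a number, and it differs from compound 1 in more than one place, so steps to it cannot be read.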